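Taking One Methyl Off a Weak Inhibitor

The compounds below may be only part of what the source reports. "The series", "measured", "known", "first", "only" and "open" are said of these compounds alone.

In a functional assay on KB cells (Homo sapiens) for inhibition (a lower number here means a stronger inhibitor, a higher number a weaker inhibitor), compound 1 `COc1ccc(Cn2c(N)c(C#N)c3c(N)ncnc32)cc1` gives 50000 nM. For compound 2 `Cc1cccc(Cn2c(N)c(C#N)c3c(N)ncnc32)c1` the reading is > 100000 nM, which is a limit of this assay and not a number. Compound 3 `N#Cc1c(N)n(Cc2ccccc2)c2ncnc(N)c12` carries hydrogen in place of methyl on an aromatic carbon, so 3-methylphenyl becomes phenyl. Going by the values given here, no measured pair of compounds shows what such a change does here, so only a small shift is expected, with no firm direction. The estimated move is an at least 1.2-fold lower number from compound 2 to compound 3 (0.09 log units; that floor lies within the scatter), a step expected to stay within the scatter. For compound 3 the expected value is 80000 nM, with an estimated range from 35000 nM to 150000 nM.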

Compound 3, half-maximal inhibitory concentration: 34000 nM
Compound 3: the middle estimate sits 2.4-fold (0.37 log units) above what was measured; measured number outside the range, below it.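

Dropping the methyl from the 3-methylphenyl group gives an at least 2.9-fold lower number from compound 2 to compound 3 (0.46 log units; beyond the scatter) and is the first sign that a change at this spot can move the reading beyond the scatter. The step to the same plain phenyl from the methoxy compound is a 1.5-fold lower number from compound 1 to compound 3 (0.17 log units; within the scatter) and so sets no order between those two. The reading of compound 2 is a limit and not a number, which makes the first step a floor: the limit of > 100000 nM in this assay, at which 1 of the 3 values shown sits.

From the compounds shown here alone, whether an amine or a carboxylic acid on this phenyl would lower the number remains open. The compounds shown also cannot separate which group is present from where it sits.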